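Trifluoromethyl in place of fluorine on the pendant ring

A few compounds are considered here, and "the series" means these few. Any claim that something is new, unique, unknown or untested is made for them only; others in the source may bear on it.

Measured so far:
compound 1 `Oc1cccc(-c2cc(-c3cccc(F)c3)cc(-c3cccc(O)c3)n2)c1` — 7860 nM
compound 2 `Oc1cccc(-c2cc(-c3ccc(F)cc3)cc(-c3cccc(O)c3)n2)c1` — 6310 nM

In a functional assay on HCT-15 cells (Homo sapiens) for inhibition (on this read-out lower numbers stand for stronger inhibition and higher numbers for weaker inhibition), compound 1 gives 7860 nM, and compound 2 gives 6310 nM. Going by the values given here, the only measured step, a 1.2-fold lower number from compound 1 to compound 2 (0.10 log units; within the scatter), moves the fluorine around the pendant phenyl. Compound 2 stands at the lowest of the two numbers, though within the scatter of compound 1.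

Compound 3 `Oc1cccc(-c2cc(-c3cccc(C(F)(F)F)c3)cc(-c3cccc(O)c3)n2)c1` carries the change (3-(trifluoromethyl)phenyl in place of 4-fluorophenyl on an aromatic carbon), on an aromatic carbon of a six-membered aromatic ring with 1 nitrogen, opposite the ring nitrogen. No measured step bears on a trifluoromethyl group; the one step shown, from compound 1 to compound 2, was within the scatter, so the pendant ring seems tolerant of small changes. Compound 3 is therefore expected to stay near compound 2, with a 1.1-fold lower number from compound 2 to compound 3 (0.02 log units; within the scatter), estimated at 6000 nM in this assay, within a range from 2500 nM to 15000 nM.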

Compound 3, half-maximal inhibitory concentration: 13600 nM
The estimate for compound 3 lay 2.3-fold (0.36 log units) below the measured number, within the range that was stated.
By their numbers in this assay, from the lowest: compounds 2, 1 and 3 (each within the scatter of the next, the first and the last beyond it).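

In this assay, the pendant ring opposite the ring nitrogen proves not wholly indifferent to change: 3-(trifluoromethyl)phenyl in place of 4-fluorophenyl gives a 2.2-fold higher number from compound 2 to compound 3 (0.33 log units; beyond the scatter), a modest step but the first in this series beyond the scatter. Trifluoromethyl in place of fluoro gives a 1.7-fold higher number from compound 1 to compound 3 (0.24 log units; within the scatter), which stays within the scatter, so the trifluoromethyl group on its own is not shown to matter, and the one step beyond the scatter alters both the group and where it sits on the pendant ring. Nothing given here accounts for that step.

Open, on these data alone, is how 4-(trifluoromethyl)phenyl would compare with compound 2, since that pair would differ only in fluoro against trifluoromethyl. Also open, as far as these compounds go, is what an amine or a carboxylic acid on the pendant ring would do.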